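Chloro in place of nitro: lipophilicity notes on the series

The compounds below may be only part of what the source reports. "The series", "measured", "known", "first", "only" and "open" are said of these compounds alone.

Of the compounds shown here, three have been measured in a physicochemical assay for lipophilicity, measured as octanol-water partition; a higher number here means a more lipophilic compound, a lower number a more polar compound. Compound 1 `O=C(COc1cccc2ccccc12)N/N=C/c1ccc(Cl)cc1` gives 4.54. Compound 3 `O=C(COc1cccc2ccccc12)N/N=C/c1ccc([N+](=O)[O-])cc1` gives 3.97. Compound 2 `C/C(=N\NC(=O)COc1cccc2ccccc12)c1ccc([N+](=O)[O-])cc1` gives 3.37, the lowest of the three numbers, with compound 3 nearest to it and compound 1 furthest, both beyond the scatter.

Compound 3 and compound 1 differ in one place only, (chloro in place of nitro on an aromatic carbon), and the step in this assay is a number 0.57 log units higher from compound 3 to compound 1 (beyond the scatter). Among the measured compounds shown here, compound 2 and compound 3 differ in more than one place; the difference between the two cores is not broken down here, and their values in this assay show only that compound 3 stands higher than compound 2, beyond the scatter.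

Compound 4 `C/C(=N\NC(=O)COc1cccc2ccccc12)c1ccc(Cl)cc1` has not yet been measured in this assay. From compound 2 it differs by chloro in place of nitro on an aromatic carbon. The place of the change reads word for word as it does between compound 3 and compound 1, so it is taken as the same change, made here on the core of compound 2. The step from compound 2 to compound 4 is expected to be a number 0.57 log units higher from compound 2 to compound 4 (beyond the scatter), resting on the measured step of a number 0.57 log units higher from compound 3 to compound 1 (beyond the scatter) between the two compounds that share the other core. Compound 4 is accordingly expected to give about 3.94 in this assay. For compound 4 the expected range runs from 3.6 to 4.3.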

Compound 4, partition coefficient: 4.17
For compound 4 the middle estimate is 0.23 log units below the measured one, and the stated range covers the measured number.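

In this assay, the step for chloro in place of nitro on the core of compound 2 is a number 0.80 log units higher from compound 2 to compound 4 (beyond the scatter), and on the core of compound 3 it is a number 0.57 log units higher from compound 3 to compound 1 (beyond the scatter), so the change runs in the same direction on both cores and none of the four compounds goes against this. Among the compounds shown here, this supports carrying 4-nitrophenyl to 4-chlorophenyl between these two cores, but it rests on one pair of groups and only two cores, so it does not show that the change would carry in the same way onto any other core or that other replacements of nitro would carry at all. No measurement at hand speaks to what lies behind the step on either core.

The compounds shown leave open whether an amine or a carboxylic acid in the place of nitro, on an aromatic carbon of the same ring, would also shift the number in step on both cores. They also leave open whether the change from nitro to chloro would hold on a core carrying a longer chain in the link to the shared amide.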